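The compounds below may be only part of what the source reports. "The series", "measured", "known", "first", "only" and "open" are said of these compounds alone.

Working notes on the series. In a functional assay on HL-60 cells (Homo sapiens) for activation, read by flow cytometry, with a stated time of 4 days (on this read-out lower numbers stand for an effect already at smaller amounts and higher numbers for an effect only at larger amounts of compound), compound 1 `COc1ccc(-n2cnc3cnc(-c4ccc(F)cc4C)cc32)cc1` gives 6 nM, compound 2 `FC(F)Oc1ccc(-n2cnc3cnc(-c4ccccc4OC(F)(F)F)cc32)cc1` gives 6900 nM and compound 3 `CCc1ccccc1-c1cc2c(cn1)ncn2-c1ccc(OC(F)F)cc1` gives 2900 nM. Compound 3 therefore holds the second highest number of the three: its nearest neighbour is compound 2, and the gap to compound 1 is by far the widest, compound 1 sitting far lower on this assay. Among the measured compounds shown here, the only single-point step on record is a 2.4-fold lower number from compound 2 to compound 3 (0.38 log units; beyond the scatter), a modest shift of the ortho substituent on the pendant phenyl.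

Compound 4 `Cc1nc(F)ccc1-c1cc2c(cn1)ncn2-c1ccc(OC(F)F)cc1` is next. The change is 6-fluoro-2-methylpyridin-3-yl in place of 2-ethylphenyl on an aromatic carbon. For the measured compounds named here, no measured step covers this exact exchange, and compound 1 differs from compound 3 in two places at once, so its low number can only hint that a methyl together with a fluorine on the pendant ring is compatible with strong activation. Going by the values given here, the same aromatic ring position is changed again here; the only recorded step at that position, a 2.4-fold lower number from compound 2 to compound 3 (0.38 log units; beyond the scatter), was modest, so some movement is expected, and the direction is taken to be downward, with the ring nitrogen and fluorine as the uncertain part. The expected step is a 12-fold lower number from compound 3 to compound 4 (1.06 log units; beyond the scatter). Compound 4 is estimated at 250 nM, with a range from 40 nM to 1500 nM.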

Compound 4, half-maximal effective concentration: 2000 nM
The estimate for compound 4 lay 8.0-fold (0.90 log units) below the measured number, outside the stated range (above it).
By their numbers in this assay, from the lowest: compound 1; then compounds 4 and 3 (each within the scatter of the next); then compound 2.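

In this assay, putting 6-fluoro-2-methylpyridin-3-yl in place of 2-ethylphenyl gives a 1.5-fold lower number from compound 3 to compound 4 (0.16 log units; within the scatter) and so leaves the two compounds indistinguishable: at this position, a ring nitrogen, a fluorine and a methyl in place of the ethyl, taken together, produce no readable shift. The earlier step on the same aromatic carbon, a 2.4-fold lower number from compound 2 to compound 3 (0.38 log units; beyond the scatter) with a different exchange, shows that this position does not answer every exchange in the same way, and the hydrogen-bond acceptor that enters with the pyridine ring comes with no separable effect on the number. Nothing available explains this result.

From the compounds shown here alone, compound 1 at 6 nM differs from compound 4 in two places, its methoxy and its carbon-only pendant ring, so the share of each in that low number stays open. Also open, going by these compounds, is how this position responds to groups of another kind, such as an amine, a carboxylic acid or a chain longer than ethyl on the pendant ring.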